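Methoxy for Methyl on a Carbonyl Carbon: Compound 3

The source may report more compounds than this note shows. Statements on the series, on what has been measured and on what is new or still open speak of the compounds shown alone.

Two compounds have numbers in a functional assay for agonist activity at follicle-stimulating hormone receptor (Homo sapiens), read by a luciferase reporter; on this read-out lower numbers stand for an effect already at smaller amounts and higher numbers for an effect only at larger amounts of compound:
compound 1, `CCCCCCN1C(=O)[C@H](Cc2ccc(-c3cccc(CN(CCCC)C(C)=O)c3)cc2)N(C)C(=O)[C@@H]1C`, 150 nM
compound 2, `CCCCCCCCN1C(=O)[C@H](Cc2ccc(-c3cccc(CN(CCCC)C(C)=O)c3)cc2)N(C)C(=O)[C@@H]1C`, 14 nM

Within the data shown here, compound 1 gives the highest of these two numbers; the only step measured, an 11-fold lower number from compound 1 to compound 2 (1.03 log units; beyond the scatter), changes the chain on the ring nitrogen, not the acetyl group. Compound 3, `CCCCCCN1C(=O)[C@H](Cc2ccc(-c3cccc(CN(CCCC)C(=O)OC)c3)cc2)N(C)C(=O)[C@@H]1C`, differs from compound 1 by methoxy in place of methyl on a carbonyl carbon. Among the measured compounds shown here, no measured step touches this carbonyl carbon, so nothing known bears on it directly. The step of no change at the digits printed from compound 1 to compound 3 (within the scatter) is therefore expected to stay within the scatter. Compound 3 is estimated at 150 nM, between 50 nM and 450 nM, in this assay.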

Compound 3, half-maximal effective concentration: 8.9 nM
Compound 3: middle estimate off by 17-fold (1.23 log units), on the high side; measured number below the stated range.
By their numbers in this assay, from the lowest: compounds 3 and 2 (each within the scatter of the next); then compound 1.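

In this assay, the carbonyl carbon of the acetyl group proves to be a position that responds to change: methoxy in place of methyl gives a 17-fold lower number from compound 1 to compound 3 (1.23 log units; beyond the scatter). Until now only the chain on the ring nitrogen had been seen to move the number, and this single-atom-scale exchange at a separate place on the molecule produces a large step too. Nothing available gives a cause for this step.

The compounds shown leave open how an ethoxy or a dimethylamino group on this carbonyl carbon would read. They also leave open whether methoxycarbonyl and the longer chain of compound 2 would add up when combined in one molecule.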